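The source may report more compounds than this note shows. Statements on the series, on what has been measured and on what is new or still open speak of the compounds shown alone.

Compound 1: `CCc1cccc2c(OC)c(-c3occ(C)c3CBr)ccc12`, in a functional assay on KBVIN cells (Homo sapiens) for cytotoxicity, read by MTT assay, with a stated time of 72 h (on this read-out higher numbers stand for an effect only at larger amounts of compound and lower numbers for an effect already at smaller amounts), compound 1 gives only a limit, > 10 ug/mL.
Compound 2: `CCc1cccc2c(OC)c(-c3occ(C)c3COC(C)=O)ccc12`, in this assay compound 2 gives only a limit, > 10 ug/mL.

Compound 2 thus stands at the limit of this assay, as does compound 1, and the step that the two limits leave unreadable from compound 1 to compound 2 cannot be read; both values sit at the limit of > 10 ug/mL in this assay, at which 2 of the 2 values shown sit. Compound 3 `CCc1cccc2c(OC)c(-c3occ(C)c3COC(=O)CCN(CC)CC)ccc12` differs from compound 2 by (diethylamino)methyl in place of hydrogen on a saturated chain carbon bound to a carbonyl carbon. For the measured compounds named here, no measured step bears on this change, and compound 2 itself is known only as a limit, so no shift beyond the scatter can be expected in this assay. Compound 3 is estimated at 10 ug/mL (range 3 ug/mL to 30 ug/mL), an expected step of a number no higher from compound 2 to compound 3 (the limit leaves the size open).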

Compound 3, concentration for half-maximal effect: > 10 ug/mL
Compound 3 gave a limit, no number (the forecaster's own chance of this, stated with the estimate: 65%); the middle value lies on the limit itself.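

No step among compound 1, compound 2 and compound 3 can be read in this assay, since all three give only a limit: the limit of > 10 ug/mL in this assay, at which 3 of the 3 values shown sit.

From the compounds shown here alone, how far each compound lies past that limit, and whether these side-chain changes affect the read-out at all, stays open.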